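From Carbamoyl to Sulfonyl on a Shared Core

The source may hold more compounds than are shown below. What is called first, only, known or untested is meant among the compounds shown, and "the series" means these compounds.

Measured in a functional assay on K562 cells (Homo sapiens) for inhibition, read by trypan blue exclusion, with a stated time of 72 h; on this read-out lower numbers stand for stronger inhibition and higher numbers for weaker inhibition:
- compound 1 `Cn1c(=O)c(C(=O)Nc2ccc(F)cc2F)cc2cnc(Nc3ccc4[nH]ccc4c3)nc21` gives 5000 nM
- compound 2 `CCCn1c(=O)c(S(=O)(=O)c2ccc(F)cc2F)cc2cnc(Nc3ccc4[nH]ccc4c3)nc21` gives 1000 nM
- compound 3 `Cn1c(=O)c(S(=O)(=O)c2ccc(F)cc2F)cc2cnc(Nc3ccc4occc4c3)nc21` gives 15000 nM

Compound 1 holds the second highest of the three numbers in this assay and so stands in the middle of this small set. Compound 4 `Cn1c(=O)c(S(=O)(=O)c2ccc(F)cc2)cc2cnc(Nc3ccc4[nH]ccc4c3)nc21` is still unmeasured and carries (4-fluorophenyl)sulfonyl in place of (2,4-difluorophenyl)carbamoyl on an aromatic carbon. Within the data shown here, no measured pair differs in one place only, so this change has no direct precedent. The two measured sulfonyl compounds point in opposite directions. Compound 2 gives 1000 nM as a lower number than compound 1, while compound 3 gives 15000 nM as a higher one, and both also differ from compound 4 elsewhere. Compound 4 shares more of its remaining structure with compound 2, so a modest move towards a lower number is expected, though one within the scatter remains possible. The expected change is a 2.0-fold lower number from compound 1 to compound 4 (0.30 log units; within the scatter) in this assay as a rough estimate. The estimate for compound 4 is 2500 nM with an expected range from 600 nM to 10000 nM in this assay on this limited evidence.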

Compound 4, half-maximal inhibitory concentration: 200 nM
For compound 4 the middle estimate is 13-fold (1.10 log units) above the measured one; measured number below the stated range.
By their numbers in this assay, from the lowest: compound 4; then compound 2; then compound 1; then compound 3.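

In this assay, putting (4-fluorophenyl)sulfonyl in place of (2,4-difluorophenyl)carbamoyl on this aromatic carbon gives a 25-fold lower number from compound 1 to compound 4 (1.40 log units; beyond the scatter) as a large step, which shows that the read-out is highly sensitive to the group at this position of the shared core. The two groups differ both in the link to the phenyl ring and in the fluorine pattern on that ring, so the step belongs to the exchange as a whole and cannot be divided between those parts. Nothing available here explains the size of this step.

The compounds shown leave open whether the link or the fluorine pattern carries the step, a question that (4-fluorophenyl)carbamoyl on the same core would address. They also leave open how this position responds to quite different groups, such as an amine or a carboxylic acid.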